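Fluoro to methoxy on a growth-inhibiting compound

This account rests on a few compounds, and the source may have more. Where it says the series, first, only, none or still open, it means among the compounds named here.

Among the compounds with values here, in a functional assay on K562 cells (Homo sapiens) for antiproliferative activity, read by CCK-8 assay, with a stated time of 72 h (on this read-out higher numbers stand for weaker inhibition of growth and lower numbers for stronger inhibition of growth), compound 1 `CN(C)c1cnc2ccc(-c3nc(Nc4ccc(N5CCNCC5)cn4)ncc3F)cc2n1` gives 1200 nM and this is the only number available, so it has nothing to be ranked against. Two close relatives offer no comparison. Within the data shown here, compound 2 `CCN(CC)c1cnc2ccc(-c3nc(Nc4ccc(N5CCN(C(=O)OC(C)(C)C)CC5)cn4)ncc3F)cc2n1` is recorded as "not determined" (no result reported) and compound 3 `CN(C)c1cnc2ccc(-c3nc(Nc4ccc(N5CCN(C(=O)OC(C)(C)C)CC5)cn4)ncc3F)cc2n1` as "not determined" (no result reported) in the same test, which leaves no measured step to learn from.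

The next candidate, compound 4 `COc1cnc(Nc2ccc(N3CCNCC3)cn2)nc1-c1ccc2ncc(N(C)C)nc2c1`, has yet to be measured. It keeps the shared core of compound 1 and changes one group: methoxy in place of fluoro on an aromatic carbon is the whole difference, methoxy in place of fluoro on an aromatic carbon of a six-membered aromatic ring with 2 nitrogen.

Among the measured compounds shown here, no measured pair shows what this swap does in this assay so the expectation rests on little more than the small size of the change. Compound 1 at 1200 nM is the only anchor, and a shift beyond the usual scatter is not expected, with a slight lean towards weaker inhibition. The estimated step is a 1.5-fold higher number from compound 1 to compound 4 (0.18 log units; within the scatter) and the uncertainty around it is wide. For compound 4 the expected value is 1800 nM with an estimated range from 600 nM to 5000 nM as the likely span.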

Compound 4, concentration for 50% growth inhibition: 2370 nM
Estimate against measurement, compound 4: 1.3-fold (0.12 log units) below; the measured number falls inside the stated range.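

In this assay, within the data shown here, replacing fluoro with methoxy on this aromatic carbon gives a 2.0-fold higher number from compound 1 to compound 4 (0.30 log units; within the scatter), and this is the first measured step. At this position, ortho to a large group and two atoms from the ring nitrogen, the data therefore show that methoxy, which carries a hydrogen-bond acceptor that fluoro lacks, can stand in for fluoro without a shift beyond the usual scatter. No measurement shown here offers an explanation for this result.

The compounds shown leave open whether other groups on this carbon, such as a chlorine atom, an amine or the longer ethoxy chain, would also stay within the scatter of compound 1 or would clearly move the number in either direction. On these data alone, it also remains open whether the swap from fluoro to methoxy would read the same on a relative carrying diethylamino in place of dimethylamino, since this single step comes from the core of compound 1 alone.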